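This account rests on a few compounds, and the source may have more. Where it says the series, first, only, none or still open, it means among the compounds named here.

Measured so far:
compound 1, `O=C(OCc1ccccc1)[C@@H]1CCCN1C(=O)CN(c1nc(Cl)nc2[nH]cnc12)C1CC1`: 33.2%
compound 2, `CC[C@H](C)[C@H](NC(=O)CN(c1ncnc2c1ncn2C1CCCCO1)C1CC1)C(=O)OCc1ccccc1`: 25.6%

Both were tested in a functional assay on the whole organism (Tail, strain ICR) with Mus musculus as the target, in the tail flick test, with a stated time of 30 min, at a dose of 25 umol/kg by the oral route; on this read-out higher numbers stand for a stronger effect at the one dose given and lower numbers for a weaker effect. Compound 1 gives 33.2%. Compound 2 gives 25.6%, and the value of compound 1 lies within the usual scatter of it, so the two compounds cannot be told apart on these numbers. Within the data shown here, no pair of measured compounds differing in a single place is available, so no measured step can guide what a single change does.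

Compound 3, `N=C(N)NCCC[C@H](NC(=O)CN(c1ncnc2c1ncn2C1CCCCO1)C1CC1)C(=O)OCc1ccccc1`, has not yet been tested. It differs from compound 2 in one place: a group of 7 heavy atoms (4 carbon, 3 nitrogen; no ring) in place of a group of 4 heavy atoms (4 carbon; no ring), on a saturated chain carbon bound to an amide-type nitrogen and a carbonyl carbon The sec-butyl leaves and the entering group takes its place on the saturated chain carbon bound to an amide-type nitrogen and a carbonyl carbon. Nothing measured here shows how such a change acts in this assay, so the expected step from compound 2 to compound 3 is a number 0.6 percentage points lower from compound 2 to compound 3 (within the scatter), a step of no clear direction that is expected to stay within the scatter. For compound 3 the estimate in this assay is 25%, with an expected range from 8% to 45%.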

Compound 3, a percentage reported as activity, at one dose (the size of the read-out at that dose, not a potency): 34.3%
Compound 3: the middle estimate sits 9.3 percentage points below what was measured; the range from low to high includes it.
By their numbers in this assay, from the lowest: compounds 2, 1 and 3 (each within the scatter of the next).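

In this assay, replacing the sec-butyl with a group of 7 heavy atoms, including 3 nitrogen atoms and 3 hydrogen-bond donors, gives a number 8.7 percentage points higher from compound 2 to compound 3 (within the scatter). Among these compounds, this is the first measured sign of what this position accepts: on the saturated chain carbon bound to an amide-type nitrogen and a carbonyl carbon, a larger, nitrogen-bearing group with no ring and a compact carbon-only group cannot be told apart at this single dose. Nothing available here accounts for this outcome.

Going by these compounds, whether a simple amine, a carboxylic acid or a longer carbon chain in this place would give a clearly different reading remains open. A single-dose reading also leaves open whether the two compounds would still read alike at other doses.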